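A few compounds are considered here, and "the series" means these few. Any claim that something is new, unique, unknown or untested is made for them only; others in the source may bear on it.

Three compounds have been measured so far in a functional assay on SMMC-7721 cells (Homo sapiens) for inhibition, read by CCK-8 assay, with a stated time of 72 h, tested at 2 uM; a lower number here means less inhibition of growth, a higher number more inhibition of growth at the concentration tested

- Compound 1 `CCc1ccc(SCc2ccc(C(=O)Nc3ccccc3N)cc2)cc1` gives 25.7%
- Compound 2 `CC(C)(C)c1ccc(SCc2ccc(C(=O)Nc3ccccc3N)cc2)cc1` gives 23.6%
- Compound 3 `Nc1ccccc1NC(=O)c1ccc(CSc2ccc(F)cc2)cc1` gives 6.58%

Compound 3 stands lowest of the three, with both other compounds clearly higher. Compound 4 `Nc1ccccc1NC(=O)c1ccc(CSc2ccc(Cl)cc2)cc1` differs from it in one place only, and the change is chloro in place of fluoro on an aromatic carbon with chloro in place of fluoro on an aromatic carbon, para to a large group.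

Two measured steps change the group at this same place. One is the step of a number 19.1 percentage points lower from compound 1 to compound 3 (beyond the scatter) and the other is the step of a number 17 percentage points lower from compound 2 to compound 3 (beyond the scatter) and both are modest. The step of a number 2.1 percentage points lower from compound 1 to compound 2 (within the scatter) shows no real difference between ethyl and tert-butyl. Going by the values given here, no measured compound carries chloro, so these steps only suggest that leaving fluoro may recover part of the lost inhibition.

A small upward change is expected, namely a number 7.4 percentage points higher from compound 3 to compound 4 (within the scatter) and it may well stay inside the usual scatter. Compound 4 is estimated at 14% with an expected range from 5% to 28% in this assay for now.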

Compound 4, percent growth inhibition at one concentration: 2.93%
Compound 4: middle estimate off by 11.1 percentage points, on the high side; the measured number lies below the stated range.
By their numbers in this assay, from the lowest: compounds 4 and 3 (each within the scatter of the next); then compounds 2 and 1 (each within the scatter of the next).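

Putting chloro in place of fluoro at this position, on the ring para to a large group, gives a number 3.7 percentage points lower from compound 3 to compound 4 (within the scatter) in this assay, so these two groups cannot be told apart here. Chloro also falls as far short of the larger carbon groups as fluoro did, with a number 20.7 percentage points lower from compound 2 to compound 4 (beyond the scatter) and a number 22.8 percentage points lower from compound 1 to compound 4 (beyond the scatter), so the four compounds form two clear pairs, ethyl and tert-butyl above, fluoro and chloro below, and none goes against this split. Nothing at hand explains why the compounds divide this way.

Only four groups are shown at this position, so it remains open where a methoxy group, an amine or a carboxylic acid would fall. A reading at a single concentration also leaves open how these compounds would compare across a range of concentrations.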